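A few compounds are considered here, and "the series" means these few. Any claim that something is new, unique, unknown or untested is made for them only; others in the source may bear on it.

Measured so far:
compound 1 `O=C1C=CCC/C1=C\C=C\c1ccccc1` with 7100 nM 
compound 2 `O=C1C=CCC/C1=C\C=C\c1ccccc1[N+](=O)[O-]` with 6800 nM 

Going by the values given here, in a functional assay on HepG2 cells (Homo sapiens) for cytotoxicity, read by MTT assay, with a stated time of 72 h (on this read-out higher numbers stand for weaker inhibition and lower numbers for stronger inhibition), compound 1 stands at 7100 nM and has compound 2 as its only measured neighbour, the two values lying within the scatter of each other. The step to compound 3 `CC(=O)Oc1ccc(/C=C/C=C2\CCC=CC2=O)cc1` is acetoxy in place of hydrogen on an aromatic carbon and amounts to acetoxy in place of hydrogen on an aromatic carbon, para to a large group. Among the compounds with values here, only one measured step bears on it, nitro in place of hydrogen on an aromatic carbon, which gave a 1.0-fold lower number from compound 1 to compound 2 (0.02 log units; within the scatter) on the same read-out. That single case involves another group and guides only loosely. Even so, no step beyond the scatter is expected in this assay for this change, in either direction. The estimated move is a 1.2-fold lower number from compound 1 to compound 3 (0.07 log units; within the scatter) on present evidence. For compound 3 the expected value is 6000 nM within an estimated range from 2500 nM to 14000 nM as the likely span.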

Compound 3, half-maximal inhibitory concentration: 4500 nM
Compound 3: middle estimate off by 1.3-fold (0.12 log units), on the high side, and the stated range covers the measured number.
By their numbers in this assay, from the lowest: compounds 3, 2 and 1 (each within the scatter of the next).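

In this assay, acetoxy in place of hydrogen on an aromatic carbon, para to a large group, gives a 1.6-fold lower number from compound 1 to compound 3 (0.20 log units; within the scatter) and so does not move the number beyond the scatter. Going by these compounds alone, this is the first reading at this place on the ring, and it shows that a group of 4 heavy atoms with 2 hydrogen-bond acceptors can sit there and leave compound 3 within the scatter of compound 1. No measurement at hand explains this result or connects it to any property of the group.

The compounds shown leave open whether a hydroxyl, an amine or a carboxylic acid at this same place would give a step beyond the scatter. They also leave open whether a longer chain in place of the acetyl part of acetoxy would do so.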